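The compounds below may be only part of what the source reports. "The series", "measured", "known", "first", "only" and "open" are said of these compounds alone.

Compound 1 `CC(=O)c1cc(C(=O)c2ccccc2)c(=O)[nH]c1C`: 2%
Compound 2 `O=C(c1ccccc1)c1cc(C(=O)c2ccccc2)c(=O)[nH]c1-c1ccccc1`: 1.76%
Compound 3 `O=C1CC(c2ccccc2)Cc2[nH]c(=O)c(C(=O)c3ccccc3)cc21`: 5.2%

All three were tested in an assay on isolated protein for inhibition of 3',5'-cyclic-AMP phosphodiesterase 4A (Cavia porcellus), read by cAMP accumulation, tested at 10 uM; a lower number here means a weaker effect, a higher number a stronger effect of the compound at the concentration tested. Compound 2 gives the lowest of the three numbers, yet compound 1 and compound 3 both lie within the scatter of it, so the three compounds cannot be put in any order; all of them show only slight inhibition at the concentration tested. Compound 4 `O=C(c1ccccc1)c1cc(S(=O)(=O)c2ccccc2)c(=O)[nH]c1-c1ccccc1` has not been measured. It differs from compound 2 in one place: phenylsulfonyl in place of benzoyl on an aromatic carbon. Among the measured compounds shown here, no pair of measured compounds differs in a single place, so no measured step shows what such a change does here. Because compound 2 gives only 1.76% in this assay, compound 4 is expected to stay near the bottom as well, with a step of a number 1.2 percentage points higher from compound 2 to compound 4 (within the scatter) that is estimated to lie within the scatter. Compound 4 is expected to give about 3%, in a range from 0% to 12%.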

Compound 4, a percentage reported as inhibition, at one concentration (the size of the read-out at that concentration, not a potency): 0%
Compound 4: the middle estimate sits 3 percentage points above what was measured; the measured number falls inside the stated range.
By their numbers in this assay, from the lowest: compounds 4, 2, 1 and 3 (each within the scatter of the next).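

Placing phenylsulfonyl in place of benzoyl on this aromatic carbon gives the first comparison in this assay of compounds that differ in one place: the step is a number 1.8 percentage points lower from compound 2 to compound 4 (within the scatter), so the two groups cannot be told apart here. Both compounds show only slight inhibition at most, so this pair cannot reveal how strongly the position matters. No other measurement bears on this result.

On these data alone, an amine or a carboxylic acid on this carbon remains open. So does whether phenylsulfonyl reads the same on the cores of compound 1 and compound 3.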